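Ethyl on the chain: expecting little change from compound 2

A few compounds are considered here, and "the series" means these few. Any claim that something is new, unique, unknown or untested is made for them only; others in the source may bear on it.

Compound 1 `CO/C=C(\C=C\c1ccc(OC)c(O)c1)c1cc(OC)c(OC)c(OC)c1` gives 5630 nM
Compound 2 `C=C(/C=C/c1ccc(OC)c(N)c1)c1cc(OC)c(OC)c(OC)c1` gives 234 nM
Compound 3 `CC=C(/C=C/c1ccc(OC)c(N)c1)c1cc(OC)c(OC)c(OC)c1` gives 217 nM

These three values come from a functional assay on HeLa cells (Homo sapiens) for antiproliferative activity, read by MTT assay, with a stated time of 48 h; on this read-out higher numbers stand for weaker inhibition and lower numbers for stronger inhibition. Compound 2 at 234 nM stands level with compound 3 within the scatter, and compound 1 at 5630 nM gives a far higher number than either. Compound 4 `CCC=C(/C=C/c1ccc(OC)c(N)c1)c1cc(OC)c(OC)c(OC)c1` has not yet been measured. Its structure departs from that of compound 2 in one place: ethyl in place of hydrogen on a double-bonded chain carbon bound to a double-bonded chain carbon, which in words is ethyl in place of hydrogen on a double-bonded chain carbon bound to a double-bonded chain carbon.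

Within the data shown here, only one measured step bears on this change. Methyl in place of hydrogen at that same kind of carbon gave a 1.1-fold lower number from compound 2 to compound 3 (0.03 log units; within the scatter). Among the measured compounds shown here, no measured compound carries ethyl there, so the evidence stops at the smaller group and the range has to stay wide. With the methyl step this small, no shift beyond the scatter is expected in this assay, and no direction can be favoured. The estimated step is a 1.0-fold higher number from compound 2 to compound 4 (0.01 log units; within the scatter). For compound 4 the expected value is 240 nM, with an estimated range from 110 nM to 520 nM.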

Compound 4, half-maximal inhibitory concentration: 314 nM
For compound 4 the middle estimate is 1.3-fold (0.12 log units) below the measured one; the measured number falls inside the stated range.
By their numbers in this assay, from the lowest: compounds 3, 2 and 4 (each within the scatter of the next); then compound 1.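

In this assay, ethyl in place of hydrogen on a double-bonded chain carbon bound to a double-bonded chain carbon gives a 1.3-fold higher number from compound 2 to compound 4 (0.13 log units; within the scatter), so this carbon has now carried a group of 2 heavy atoms, and not only methyl, without a shift beyond the scatter. Extending the chain further, with methyl in place of hydrogen on a saturated chain carbon bound to a double-bonded chain carbon, gives a 1.4-fold higher number from compound 3 to compound 4 (0.16 log units; within the scatter), which means that hydrogen, methyl and ethyl at this carbon cannot be told apart in this assay. Nothing in the available data offers an explanation for this flat result.

The compounds shown leave open how far this flat stretch extends: a longer chain such as butyl, a branched group such as isopropyl, or a chain ending in an amine or a carboxylic acid could still move the number beyond the scatter. Compound 1 differs from the others in more than one place, so the value of compound 1 at 5630 nM cannot be tied to any single one of those differences.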